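The source may report more compounds than this note shows. Statements on the series, on what has been measured and on what is new or still open speak of the compounds shown alone.

Two compounds share one core and differ only in the group attached to the carbonyl carbon of their amide. Compound 1 `CCCN(CC[C@H]1CC[C@H](NC(=O)/C=C/c2cccc(OC)c2)CC1)[C@H]1CCc2nc(N)sc2C1` carries a 2-(3-methoxyphenyl)ethenyl group there, and in an assay on brain for displacement of a labelled ligand from D(3) dopamine receptor (Rattus norvegicus) (a higher number here means a weaker inhibitor, a lower number a stronger inhibitor), compound 1 gives 9.3 nM. Compound 2 `CCCN(CC[C@H]1CC[C@H](NC(=O)c2ccc(-n3cccn3)cc2)CC1)[C@H]1CCc2nc(N)sc2C1` carries a 4-(1H-pyrazol-1-yl)phenyl group in the same place, and in this assay compound 2 gives 3 nM. That exchange produced a 3.1-fold lower number from compound 1 to compound 2 (0.49 log units; beyond the scatter). Among the two numbers measured so far, compound 2 therefore stands at the lower one, with compound 1 as its only neighbour.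

Compound 3 `CCCN(CC[C@H]1CC[C@H](NC(=O)c2ccc(-c3noc(C)n3)cc2)CC1)[C@H]1CCc2nc(N)sc2C1` keeps the whole of compound 2 except for one change: 5-methyl-1,2,4-oxadiazol-3-yl in place of 1H-pyrazol-1-yl on an aromatic carbon. Among the compounds with values here, no measured step exchanges one five-membered ring for another on that phenyl ring. Within the data shown here, the single measured step, a 3.1-fold lower number from compound 1 to compound 2 (0.49 log units; beyond the scatter), replaced the entire acyl group and was modest, so it bears on this change only loosely. A step no larger than the scatter is therefore expected, and the estimate means a 1.3-fold higher number from compound 2 to compound 3 (0.12 log units; within the scatter) from compound 2 to compound 3. On that basis compound 3 is expected to give 4 nM in this assay, with a range from 1.5 nM to 12 nM.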

Compound 3, inhibition constant: 1.3 nM
The estimate for compound 3 lay 3.1-fold (0.49 log units) above the measured number, and the stated range ends above it.
By their numbers in this assay, from the lowest: compound 3; then compound 2; then compound 1.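

Within this assay, the group para to a large group on the phenyl ring still matters once the rest of the molecule is held fixed: 5-methyl-1,2,4-oxadiazol-3-yl in place of 1H-pyrazol-1-yl gives a 2.3-fold lower number from compound 2 to compound 3 (0.36 log units; beyond the scatter) and so shows that one five-membered aromatic ring cannot simply stand in for another here. The earlier step replaced the whole acyl group, whereas this one isolates the ring at its far end, and the full exchange now amounts to a 7.2-fold lower number from compound 1 to compound 3 (0.85 log units; beyond the scatter) with both of these steps lying beyond the scatter. Nothing available here explains why the number falls with this exchange.

The exchange alters the ring and adds a methyl group in a single move, so a 1,2,4-oxadiazol-3-yl ring with only a hydrogen at that carbon, or a 5-ethyl-1,2,4-oxadiazol-3-yl group, would be needed to tell how much of the step belongs to the methyl group. Whether a simple amine or a carboxylic acid could take the place of the five-membered ring also stays open, since the compounds shown carry only these two rings on the phenyl group.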